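Shortening the Alkyl Chain on a Second Core

The compounds below may be only part of what the source reports. "The series", "measured", "known", "first", "only" and "open" are said of these compounds alone.

Compound 1 `CCCCc1nc2ncccc2n1Cc1cc(Cl)c(O)c(Cl)c1` and compound 2 `CCCc1nc2ncccc2n1Cc1cc(Cl)c(O)c(Cl)c1` share a core and differ in only one place; compound 3 `CCCCc1nc2c(C)ccnc2n1Cc1cc(Cl)c(O)c(Cl)c1` carries a different core with the same side chain as compound 1, and compound 4 `CCCc1nc2c(C)ccnc2n1Cc1cc(Cl)c(O)c(Cl)c1` bears the core of compound 3 together with the shorter chain of compound 2. In a functional assay (aorta) with Oryctolagus cuniculus as the target (a lower number here means tighter binding, a higher number weaker binding), compound 1 gives 398 nM and compound 2 gives 794 nM. The change between them is hydrogen in place of methyl on a saturated chain carbon, three bonds along the chain from an aromatic carbon, and it made a step of a 2.0-fold higher number from compound 1 to compound 2 (0.30 log units; within the scatter). Compound 3 gives 10 nM in this assay, the lowest of the three numbers; the difference between its core and that of compound 1 is not broken down here. The change from compound 3 to compound 4 is hydrogen in place of methyl on a saturated chain carbon, three bonds along the chain from an aromatic carbon, the same change at the same place. Among the measured compounds shown here, compound 3 is the only measured compound on its core, so the expectation for compound 4 rests on the step of a 2.0-fold higher number from compound 1 to compound 2 (0.30 log units; within the scatter) applied to the value of compound 3, which is 10 nM. Compound 4 is therefore expected to give 20 nM. The estimated step is a 2.0-fold higher number from compound 3 to compound 4 (0.30 log units; within the scatter). For compound 4 the estimate is expected to span 7 nM to 60 nM.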

Compound 4, dissociation constant: 1.26 nM
The estimate for compound 4 lay 16-fold (1.20 log units) above the measured number, and the stated range ends above it.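

On the core of compound 3, going from butyl to propyl gives a 7.9-fold lower number from compound 3 to compound 4 (0.90 log units; beyond the scatter) in this assay. Set beside the step on the core of compound 1, this shows that the same change does not carry over unchanged from one core to the other: the same change on two cores in this assay, a 2.0-fold higher number (0.30 log units; within the scatter) from compound 1 to compound 2 and a 7.9-fold lower number (0.90 log units; beyond the scatter) from compound 3 to compound 4, 16-fold (1.20 log units) apart, beyond the scatter of two such steps. A step read on one of these cores therefore cannot stand in for the other in this series, but with a single pair on each core the comparison does not show why the two steps part, nor what the change would do on any further core.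

The compounds shown leave open how the number moves on the core of compound 3 with a shorter chain such as ethyl or a longer chain such as pentyl. They also leave open what an amine or a carboxylic acid in place of the alkyl chain would give on either core.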